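This account rests on a few compounds, and the source may have more. Where it says the series, first, only, none or still open, it means among the compounds named here.

Working notes on the series.

Three compounds of this series have numbers in a functional assay on SK-OV-3 cells (Homo sapiens) for cytotoxicity, read by sulforhodamine B assay, with a stated time of 48 h, tested at 10 uM; a lower number here means a stronger effect, a higher number a weaker effect of the compound at the concentration tested. Compound 1, `COc1ccc(-c2cc(/C=C/C(=O)c3ccc(N)cc3)[nH]n2)cc1`, gives 23%. Compound 2, `COc1ccc(-c2cc(/C=C/C(=O)c3ccc(N)cc3)[nH]n2)cc1OC`, gives 29%. Compound 3, `COc1cc(C(=O)/C=C/c2cc(-c3cc(OC)c(OC)c(OC)c3)n[nH]2)cc(OC)c1OC`, gives 5%, the lowest of the three, with the nearest other number that of compound 1 and the furthest that of compound 2, both beyond the scatter. The difference between the core of compound 3 and that of compound 2 is not broken down here.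

One change is seen once in measured compounds: hydrogen in place of methoxy on an aromatic carbon, and it made a number 6 percentage points lower from compound 2 to compound 1 (within the scatter).

Compound 4, `COc1ccc(-c2cc(/C=C/C(=O)c3cc(OC)c(OC)c(OC)c3)[nH]n2)cc1OC`, has not yet been measured. It arises from compound 3 by the same kind of change, (hydrogen in place of methoxy on an aromatic carbon), though around the place the ring here also carries a methoxy group meta to the changed carbon, which the place in compound 1 does not. Given that compound 1 and compound 2 differ by the step of a number 6 percentage points lower from compound 2 to compound 1 (within the scatter), the expected step of a number 5 percentage points higher from compound 3 to compound 4 (within the scatter) from compound 3 is also small. Compound 4 is therefore expected at about 10%, within 2% to 30%.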

Compound 4, a percentage reported as activity, at one concentration (the size of the read-out at that concentration, not a potency): 37%
The estimate for compound 4 lay 27 percentage points below the measured number; measured number outside the range, above it.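

In this assay, hydrogen in place of methoxy on an aromatic carbon gave a number 32 percentage points higher from compound 3 to compound 4 (beyond the scatter), a large step on the core of compound 3. Set beside the earlier step, this shows that the size of the step does not carry over from one core to the other in this series: the same change on two cores in this assay, a number 6 percentage points lower (within the scatter) from compound 2 to compound 1 and a number 32 percentage points higher (beyond the scatter) from compound 3 to compound 4, 38 percentage points apart, beyond the scatter of two such steps

Going by these compounds alone, the comparison rests on only two pairs, so it does not show which feature of the two cores goes with the gap, nor whether the methoxy group meta to the changed carbon in compound 4, absent at the place in compound 1, plays any part.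

Open, as far as these compounds go, is whether the step seen with hydrogen would also appear with another group at this place, such as hydroxyl, ethoxy or fluorine. Also open, from the compounds shown here alone, is how a change at the other methoxy groups of compound 3 would read, and whether any such step would hold on a third core.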